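A few compounds are considered here, and "the series" means these few. Any claim that something is new, unique, unknown or untested is made for them only; others in the source may bear on it.

Series notes. The measure throughout is a functional assay on SW480 cells (Homo sapiens) for cytotoxicity, read by MTT assay, with a stated time of 72 h; a lower number here means a stronger inhibitor, a higher number a weaker inhibitor. Going by the values given here, compound 1 (`Cc1nnc(SCc2coc3ccc(Cl)cc3c2=O)o1`) is the one member with a number: compound 1 gives 3500 nM in this assay. Compound 2 (`O=c1cc(CSc2nc3ccccc3s2)oc2ccccc12`) returns only a limit of the assay, namely > 25000 nM. Compound 3 (`O=c1cc(CSc2nc3ccccc3o2)c2ccc(O)c(O)c2o1`) likewise returns only a limit of the assay, namely > 25000 nM. Among the compounds with values here, compound 1 therefore stands alone as the single measured value, the remaining two sitting at the limit of > 25000 nM in this assay, at which 2 of the 3 values shown sit. Within the data shown here, no two measured compounds differ in a single place, so no step can be sized from the data as they stand, and the two limits say no more than that they are limits.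

Compound 4 (`Cc1nnc(SCc2coc3ccc(Cl)cc3c2=O)s1`) has not yet been measured. It differs from compound 1 by 5-methyl-1,3,4-thiadiazol-2-yl in place of 5-methyl-1,3,4-oxadiazol-2-yl on a sulfur. The expected step of a 1.2-fold lower number from compound 1 to compound 4 (0.07 log units; within the scatter) is one of no more than the usual scatter, with no direction favoured. Compound 4 is accordingly estimated at about 3000 nM, with a range from 1200 nM to 9000 nM.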

Compound 4, half-maximal inhibitory concentration: 3200 nM
Estimate against measurement, compound 4: 1.1-fold (0.03 log units) below; the range from low to high includes it.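

In this assay, going by these compounds alone, this is the first pair that differs in one place, and it gives a 1.1-fold lower number from compound 1 to compound 4 (0.04 log units; within the scatter), with 5-methyl-1,3,4-thiadiazol-2-yl in place of 5-methyl-1,3,4-oxadiazol-2-yl on a sulfur. For this pair, the two groups cannot be told apart in this assay, so the activity of compound 1 does not depend on 5-methyl-1,3,4-oxadiazol-2-yl specifically. Nothing given here bears on why the step is so small.

Steps to compound 2 and compound 3 cannot be read, since each returns only a limit of the assay and neither differs from compound 1 or compound 4 in one place: the limit of > 25000 nM in this assay, at which 2 of the 4 values shown sit. On these data alone, whether the core of compound 1 keeps its activity with an amine, a carboxylic acid or a longer chain on this sulfur remains open.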